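The compounds below may be only part of what the source reports. "The series", "measured", "known", "first", "only" and "open" are said of these compounds alone.

Of the compounds shown here, three built on one shared core have been tested in a functional assay on A549 cells (Homo sapiens) for antiproliferative activity, read by MTT assay, with a stated time of 48 h; a lower number here means a stronger inhibitor, a higher number a weaker inhibitor. Compound 1 `N#CC1=C(N)Oc2c(c3nc4ccccc4nc3c3ccccc23)C12C(=O)N(Cc1cnnn1-c1ccc(F)cc1)c1ccccc12` returned only a limit of the assay, > 50000 nM. Compound 2 `CC(=O)Nc1ccc(-n2nncc2CN2C(=O)C3(C(C#N)=C(N)Oc4c3c3nc5ccccc5nc3c3ccccc43)c3ccccc32)cc1` likewise returned only a limit, > 50000 nM. Among the compounds with values here, the one step in hand, a step that the two limits leave unreadable from compound 1 to compound 2, is unreadable because both ends rest at the limit of > 50000 nM in this assay, at which 2 of the 3 values shown sit. Within the data shown here, compound 3 `N#CC1=C(N)Oc2c(N)cc3nc4ccccc4nc3c2C12C(=O)N(Cc1cnnn1-c1ccccc1Cl)c1ccccc12` is the sole compound with a number in this assay, giving 29800 nM. On the values shown, compound 3 therefore stands alone as the only read activity, while the other two compounds sit at a limit.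

Compound 4 `N#CC1=C(N)Oc2c(N)cc3nc4ccccc4nc3c2C12C(=O)N(Cc1cnnn1-c1ccc(Cl)cc1[N+](=O)[O-])c1ccccc12` differs from compound 3 in a single place: 4-chloro-2-nitrophenyl in place of 2-chlorophenyl on an aromatic nitrogen. Among the measured compounds shown here, no measured step bears on this change. For the measured compounds named here, the only step available concerns an acetamido in place of fluoro, and its size cannot be read. There is thus nothing in the numbers that points to a shift in either direction for this assay, and the step is expected to stay within the usual scatter. The expected step of a 1.0-fold higher number from compound 3 to compound 4 (0.00 log units; within the scatter) is accordingly taken as flat. The estimate for compound 4 is 30000 nM, with a range from 10000 nM to 90000 nM, and a real chance that this assay again reports only a limit.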

Compound 4, half-maximal inhibitory concentration: > 50000 nM
Compound 4 ended at the assay's limit; the forecaster's own chance of this, stated with the estimate: 35%; middle value at least 1.6-fold (0.22 log units) away from the limit.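

In this assay, within the data shown here, this position, on an aromatic nitrogen of the five-membered aromatic ring with 3 nitrogen, now has a step with a figure attached, where the only earlier step could not be read: 4-chloro-2-nitrophenyl in place of 2-chlorophenyl gives an at least 1.6-fold higher number from compound 3 to compound 4 (0.22 log units; that floor lies within the scatter). That figure is a floor and not a size, and as the floor lies within the scatter, the change is not shown to weaken the compound beyond repeat variation, although it brings no stronger read value either. Compound 3 remains the only compound with a number, and the limit now covers most of the set: the limit of > 50000 nM in this assay, at which 3 of the 4 values shown sit.

From the compounds shown here alone, how far the true value of compound 4 lies beyond its limit stays open, as does the question of whether the step comes from the nitro group or from the chlorine moving on the phenyl ring. Also open, going by these compounds, is whether a 2-nitrophenyl, a 4-chlorophenyl or a 4-aminophenyl group on the same nitrogen would give a number, and on which side of compound 3 that number would fall.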